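Benzoyl in place of allyl: expected cytotoxicity of compound 4

This account rests on a few compounds, and the source may have more. Where it says the series, first, only, none or still open, it means among the compounds named here.

Compound 1, `CCC1(Cc2ccccc2)OS(=O)(=O)C=C1OCC#N`, in an ADME assay on HEL cells (Homo sapiens) for cytotoxicity, with a stated time of 3 days (a lower number here means that less compound is tolerated, a higher number that more compound is tolerated), gives > 200000 nM, which is a limit of the assay.
Compound 2, `CCC1(Cc2ccccc2)OS(=O)(=O)C=C1OCc1ccc(Cl)cc1`, in this assay gives > 200000 nM, also a limit.
Compound 3, `C=CCOC1=CS(=O)(=O)OC1(CC)Cc1ccccc1`, in this assay gives > 200000 nM, again a limit.

Compound 3 thus stands only at a limit, and so do its two companions, all three sitting at the limit of > 200000 nM in this assay, at which 3 of the 3 values shown sit. The three measured steps, a step that the two limits leave unreadable from compound 1 to compound 2, a step that the two limits leave unreadable from compound 1 to compound 3 and a step that the two limits leave unreadable from compound 2 to compound 3, therefore cannot be sized. Compound 4, `CCC1(Cc2ccccc2)OS(=O)(=O)C=C1OC(=O)c1ccccc1`, differs from compound 3 by benzoyl in place of allyl on an oxygen on an unsaturated carbon. Going by the values given here, no measured step gives a readable size that bears on this change, so the expected step in this assay is a step that the limit leaves unreadable from compound 3 to compound 4, most likely nothing beyond the scatter, with the reading expected to remain at the limit. Compound 4 is estimated at 250000 nM, with a range from 100000 nM to 600000 nM.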

Compound 4, half-maximal cytotoxic concentration: > 200000 nM
Compound 4: only a limit was reported (the forecaster's own chance of this, stated with the estimate: 85%); the middle value does not contradict the limit.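

Compound 4 joins compound 1, compound 2 and compound 3 at a limit, so none of its steps to them can be read: the limit of > 200000 nM in this assay, at which 4 of the 4 values shown sit.

In this assay the compounds shown leave open where the true cytotoxic concentration of each lies, and whether any of these changes shifts it.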